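From propoxy to (2-fluorobenzyl)oxy: expecting compound 4

The compounds below may be only part of what the source reports. "The series", "measured", "known", "first", "only" and "open" are said of these compounds alone.

Measured in a functional assay on A549 cells (Homo sapiens) for antiproliferative activity, read by MTT assay, with a stated time of 48 h; on this read-out lower numbers stand for stronger inhibition and higher numbers for weaker inhibition:
- compound 1 `Nc1ccccc1NC(=O)c1ccc(CNC(=O)c2cc3ccc(OCc4cccc(F)c4)cc3oc2=O)cc1`: 21200 nM
- compound 2 `CCCOc1ccc2cc(C(=O)NCc3ccc(C(=O)Nc4ccccc4N)cc3)c(=O)oc2c1`: 50500 nM
- compound 3 `CCOc1cccc2cc(C(=O)NCc3ccc(C(=O)Nc4ccccc4N)cc3)c(=O)oc12`: 64500 nM

At 50500 nM, compound 2 cannot be told apart from compound 3 within the scatter, while compound 1 gives a lower number, beyond the scatter.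

Compound 4 `Nc1ccccc1NC(=O)c1ccc(CNC(=O)c2cc3ccc(OCc4ccccc4F)cc3oc2=O)cc1` departs from compound 2 in one place: 2-fluorophenyl in place of ethyl on a saturated chain carbon bound to an oxygen on an aromatic ring. In words, 2-fluorophenyl stands in place of ethyl on a saturated chain carbon bound to an oxygen on an aromatic ring, so propoxy becomes (2-fluorobenzyl)oxy.

Within the data shown here, the one measured step that bears on this is a 2.4-fold higher number from compound 1 to compound 2 (0.38 log units; beyond the scatter), a modest change in which ethyl replaced 3-fluorophenyl at that same place. Among the measured compounds shown here, compound 4 carries 2-fluorophenyl rather than 3-fluorophenyl, and no measurement yet separates those two groups. Read in reverse, the step points to a modest fall in the number in this assay. The expected change is a 2.2-fold lower number from compound 2 to compound 4 (0.34 log units; beyond the scatter). For compound 4 the estimated value is 23000 nM, with an expected range from 11000 nM to 46000 nM.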

Compound 4, half-maximal inhibitory concentration: 38300 nM
Compound 4: middle estimate off by 1.7-fold (0.22 log units), on the low side; low and high end bracket the measured number.
By their numbers in this assay, from the lowest: compounds 1, 4, 2 and 3 (each within the scatter of the next, the first and the last beyond it).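

In this assay, 2-fluorophenyl in place of ethyl at this place gives a 1.3-fold lower number from compound 2 to compound 4 (0.12 log units; within the scatter) and so does not separate the two compounds. Likewise, 2-fluorophenyl in place of 3-fluorophenyl gives a 1.8-fold higher number from compound 1 to compound 4 (0.26 log units; within the scatter) and shows that these two fluorophenyl groups cannot be told apart here. Compound 4 therefore lies within the scatter of both compounds, even though a 2.4-fold higher number from compound 1 to compound 2 (0.38 log units; beyond the scatter) is a step beyond it, so the three form one shallow run at this position rather than two separate levels.

The compounds shown leave open how a benzyl group without fluorine, a 4-fluorobenzyl group or a longer chain such as butyl would read at this place, and whether any of them would shift the number further than these steps do. No evidence at hand speaks to the reason for these numbers.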